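Chloro for Fluoro on the Benzyl Group

The source may hold more compounds than are shown below. What is called first, only, known or untested is meant among the compounds shown, and "the series" means these compounds.

Going by the values given here, compound 1 `O=C(NCc1cn(Cc2ccc(Cl)cc2)nn1)c1cn(-c2ccccc2)nc1-c1ccccc1` and compound 2 `COc1ccc(-c2nn(-c3ccccc3)cc2C(=O)NCc2cn(Cc3ccc(F)cc3)nn2)cc1` share a core but differ in more than one place, so no single step can be traced between them. In a functional assay on MCF7 cells (Homo sapiens) for antiproliferative activity, read by sulforhodamine B assay, with a stated time of 48 h (on this read-out higher numbers stand for weaker inhibition of growth and lower numbers for stronger inhibition of growth), compound 1 gives > 100000 nM, which is a limit of the assay rather than a number; this is the limit of > 100000 nM in this assay, at which 1 of the 2 values shown sits. In this assay compound 2 gives 460 nM, the only number shown, so it stands alone among the measured values. Compound 3 `COc1ccc(-c2nn(-c3ccccc3)cc2C(=O)NCc2cn(Cc3ccc(Cl)cc3)nn2)cc1` differs from compound 2 by chloro in place of fluoro on an aromatic carbon. Among the compounds with values here, since no pair of measured compounds differs in just one place, there is no measured step to lean on, and a change of this kind is expected to move the read-out little, if at all, beyond the scatter. Compound 3 is therefore estimated at 400 nM, with a range from 150 nM to 1200 nM. The step that this estimate means is a 1.2-fold lower number from compound 2 to compound 3 (0.06 log units; within the scatter), expected to stay within the usual scatter.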

Compound 3, concentration for 50% growth inhibition: 2900 nM
Beside the measured number, compound 3's estimate is 7.3-fold (0.86 log units) below it, outside the stated range (above it).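

In this assay, chloro in place of fluoro on an aromatic carbon gives a 6.3-fold higher number from compound 2 to compound 3 (0.80 log units; beyond the scatter), so the atom at this place on the benzyl group does affect the read-out. Compound 3 also makes a second single change readable, methoxy in place of hydrogen on an aromatic carbon, which gives an at least 34-fold lower number from compound 1 to compound 3 (1.53 log units; beyond the scatter). The value of compound 1 is a limit and not a number: the limit of > 100000 nM in this assay, at which 1 of the 3 values shown sits.

The compounds shown leave open how bromo, methyl or an amine at the place of the halogen would read, so two halogens give no trend. They also leave open whether the methoxy step would look the same with fluoro on the benzyl group, and whether a hydroxyl or an ethoxy group could stand in for methoxy.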